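From isopropoxy to isobutoxy on the shared core

This account rests on a few compounds, and the source may have more. Where it says the series, first, only, none or still open, it means among the compounds named here.

In a functional assay on P388 cells (Mus musculus) for cytotoxicity (on this read-out lower numbers stand for an effect already at smaller amounts and higher numbers for an effect only at larger amounts of compound), compound 1 `CCOc1cc(-c2ccccc2)nc2ccccc12` gives 6 ug/mL as its reading. Among the measured compounds shown here, compound 3 `Oc1cc(-c2ccccc2)nc2ccc(Cl)cc12` gives 0.84 ug/mL but differs from the others in more than one place, so it offers no step here.

Compound 2 `CC(C)Oc1cc(-c2ccccc2)nc2ccccc12` gives > 10 ug/mL as its reading, which is a limit of the assay and not a number. It stands at the limit of > 10 ug/mL in this assay, at which 1 of the 3 values shown sits, and so has no exact place on the scale.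

Compound 4 `CC(C)COc1cc(-c2ccccc2)nc2ccccc12` differs from compound 2 by isobutyl in place of isopropyl on an oxygen on an aromatic ring and keeps the rest of the structure. For the measured compounds named here, the one measured step that bears on this change is an at least 1.6-fold higher number from compound 1 to compound 2 (0.22 log units; that floor lies within the scatter) on the same oxygen chain, and it offers no size beyond the scatter to carry over. No step beyond the scatter is therefore expected in this assay for this change, and the reading may again be only a limit. The expected move is a step that the limit leaves unreadable from compound 2 to compound 4 as an estimate, with no firm direction. Compound 4 is estimated at 12 ug/mL with an expected range from 5 ug/mL to 30 ug/mL on this read-out.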

Compound 4, half-maximal effective concentration: > 10 ug/mL
Compound 4 ended at the assay's limit; the forecaster's own chance of this, stated with the estimate: 55%; the middle value lies beyond the limit too.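

The step from isopropyl to isobutyl on this oxygen cannot be read, because compound 2 and compound 4 both stand at a limit of the assay: the limit of > 10 ug/mL in this assay, at which 2 of the 4 values shown sit.

Among the compounds shown here, the one step that can be read is an at least 1.6-fold higher number from compound 1 to compound 4 (0.22 log units; that floor lies within the scatter), so isobutyl on this oxygen does not show a change from compound 1 beyond the scatter. What compound 4 adds is a second, larger chain on the oxygen that also gives no exact place on the scale in this assay.

On these data alone, how far compound 2 and compound 4 lie past the limit stays open, and so does any difference between them. Also open, as far as these compounds go, is whether a methoxy group, or a longer chain ending in an amine, on this oxygen would give a reading on the scale.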